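A few compounds are considered here, and "the series" means these few. Any claim that something is new, unique, unknown or untested is made for them only; others in the source may bear on it.

Measured in a functional assay on KB cells (Homo sapiens) for inhibition, with a stated time of 72 h; on this read-out lower numbers stand for stronger inhibition and higher numbers for weaker inhibition:
compound 1 `COc1ccc(S(=O)(=O)N2CCc3cccc(-c4ccc([N+](=O)[O-])cc4)c32)cc1` gives 52.5 nM
compound 2 `COc1ccc(S(=O)(=O)N2CCc3cccc(-c4ccc(F)c(F)c4)c32)cc1` gives 45 nM
compound 3 `COc1ccc(S(=O)(=O)N2CCc3cccc(-c4cccc(F)c4)c32)cc1` gives 98.5 nM

Only against compound 2 does compound 3 show a number that is higher beyond the scatter; against compound 1 it does not. The next compound, compound 4 `COc1ccc(S(=O)(=O)N2CCc3cccc(-c4ccc(O)cc4)c32)cc1`, has 4-hydroxyphenyl in place of 3-fluorophenyl on an aromatic carbon. For the measured compounds named here, no measured compound carries a hydroxy group, so nothing tests this exchange directly. The nearest evidence comes from the other exchanges at the same aromatic carbon, and all are small. These are a 1.2-fold lower number from compound 1 to compound 2 (0.07 log units; within the scatter) and a 1.9-fold higher number from compound 1 to compound 3 (0.27 log units; within the scatter), both within the scatter, and a 2.2-fold higher number from compound 2 to compound 3 (0.34 log units; beyond the scatter), a modest one. The three measured aryl groups thus span a narrow range, which suggests that this position tolerates different groups, at least among these compounds. The two compounds with a group named at the 4 position of the phenyl, compound 1 and compound 2, do not sit higher than compound 3, so a slightly lower number is expected, though probably no step beyond the scatter. The expected change is a 1.3-fold lower number from compound 3 to compound 4 (0.12 log units; within the scatter). Compound 4 is estimated at 75 nM, with an expected range from 30 nM to 200 nM.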

Compound 4, half-maximal inhibitory concentration: 129 nM
Beside the measured number, compound 4's estimate is 1.7-fold (0.24 log units) below it, and the stated range covers the measured number.
By their numbers in this assay, from the lowest: compounds 2, 1, 3 and 4 (each within the scatter of the next, the first and the last beyond it).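

In this assay, compound 4 is the only one shown with a hydrogen-bond donor on its aryl group, yet the exchange of 3-fluorophenyl for 4-hydroxyphenyl is a 1.3-fold higher number from compound 3 to compound 4 (0.12 log units; within the scatter), so this position accepts that group without a step beyond the scatter. The same compound does separate from the other two aryl compounds, with a 2.9-fold higher number from compound 2 to compound 4 (0.46 log units; beyond the scatter) and a 2.5-fold higher number from compound 1 to compound 4 (0.39 log units; beyond the scatter), both modest, which shows that the group at the 4 position of the phenyl can shift the number and that 4-hydroxyphenyl and 4-nitrophenyl are not interchangeable here. Nothing available explains why hydroxy and nitro differ in this way.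

The compounds shown leave open whether 4-methoxyphenyl, which carries a methyl on the hydroxy oxygen, would fall nearer compound 4 or nearer compound 1. They also leave open how an amine or a carboxylic acid at the 4 position of the phenyl would behave, and whether these small steps would hold with a different group on the sulfonyl side of the shared core.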